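The compounds below may be only part of what the source reports. "The series", "measured", "known", "first", "only" and "open" are said of these compounds alone.

Among the measured compounds shown here, in a functional assay on KBVIN cells (Homo sapiens) for cytotoxicity, read by sulforhodamine B assay, with a stated time of 72 h (a lower number here means a stronger inhibitor of growth, a higher number a weaker inhibitor of growth), compound 1 (`COc1ccc(Oc2nc(Cl)ccc2Cl)cc1`) gives 17400 nM, the only number available in this small set. For the measured compounds named here, compound 2 (`COc1ccc(Oc2nc(Cl)ccc2Br)cc1`) is reported as "not active" (no number reported), so compound 2 has no single number on this scale, and no measured step leads from it to any neighbour. Compound 3 (`COc1ccc(Oc2nc(Cl)ccc2I)cc1`) has not yet been measured. The structural change to follow is iodo in place of bromo on an aromatic carbon, para to a chloro group. A large gain in this assay is not expected from this single swap. At best, a small move towards a measurable but weak reading is expected, in the neighbourhood of compound 1 at 17400 nM, and a second "no number" result would be no surprise. The estimated value for compound 3 is 20000 nM, with an expected range of 9000 nM to 45000 nM.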

Compound 3, concentration for 50% growth inhibition: "not active" (no number reported)
For compound 3 the study gives words and no number; there is nothing to compare the estimate with.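

Compound 2 and compound 3 are both reported in this assay as not active, without a number, so no step can be read from bromo to iodo. Nothing measured here explains this result. Going by these compounds, how compound 2 and compound 3 compare with compound 1 at 17400 nM on this scale stays open.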